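The source may report more compounds than this note shows. Statements on the series, on what has been measured and on what is new or still open speak of the compounds shown alone.

Measured compounds:
compound 1, `Oc1cccc(-c2cc(-c3ccccc3F)cc(-c3ccccc3O)n2)c1`, in a functional assay on HCT-15 cells (Homo sapiens) for inhibition (a lower number here means a stronger inhibitor, a higher number a weaker inhibitor), compound 1 gives 8470 nM;
compound 2, `Oc1cccc(-c2cc(-c3ccccc3F)cc(-c3cccc(O)c3)n2)c1`, in this assay compound 2 gives 5300 nM;
compound 3, `Oc1ccccc1-c1cc(-c2cccc(OC(F)(F)F)c2)cc(-c2ccccc2O)n1`, in this assay compound 3 reports only a limit, > 50000 nM.

Compounds 1 and 2 differ in a single place: 3-hydroxyphenyl in place of 2-hydroxyphenyl on an aromatic carbon. The step is a 1.6-fold lower number from compound 1 to compound 2 (0.20 log units; within the scatter), so the two values cannot be told apart on this assay. Compound 3 sits at the limit of > 50000 nM in this assay, at which 1 of the 3 values shown sits. How the core of compound 3 differs from that of compound 1 is not broken down here.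

Compound 4, `Oc1cccc(-c2cc(-c3cccc(OC(F)(F)F)c3)cc(-c3ccccc3O)n2)c1`, has not yet been measured in this assay. It differs from compound 3 by the same kind of change that separates compound 2 from compound 1: 3-hydroxyphenyl in place of 2-hydroxyphenyl on an aromatic carbon. The surroundings are not the same word for word: in compound 1 the changed carbon is meta to a 2-fluorophenyl group and meta to a 3-hydroxyphenyl group, whereas in compound 3 it is meta to a 2-hydroxyphenyl group and meta to a large group.

Given that the one measured instance of this change, a 1.6-fold lower number from compound 1 to compound 2 (0.20 log units; within the scatter), lies within the scatter, and that compound 3 reports only a limit, compound 4 is expected to give a step of an at least 1.1-fold lower number from compound 3 to compound 4 (0.04 log units; that floor lies within the scatter), with the assay more likely than not again reporting only a limit. On that basis compound 4 is estimated at 45000 nM, between 15000 nM and 150000 nM.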

Compound 4, half-maximal inhibitory concentration: 2740 nM
Compound 4: the middle estimate sits 16-fold (1.22 log units) above what was measured; measured number outside the range, below it.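

In this assay, putting 3-hydroxyphenyl in place of 2-hydroxyphenyl next to the ring nitrogen gives an at least 18-fold lower number from compound 3 to compound 4 (1.26 log units; beyond the scatter). As far as these compounds go, compound 3 reports only a limit, > 50000 nM, so this step is a floor and its full size remains unknown. The change therefore did not carry from one core to the other at a fixed size, although two cores establish no general rule and give no reason for the difference: the same change on two cores in this assay, a 1.6-fold lower number (0.20 log units; within the scatter) from compound 1 to compound 2 and an at least 18-fold lower number (1.26 log units; beyond the scatter) from compound 3 to compound 4, at least 11-fold (1.05 log units) apart, beyond the scatter of two such steps.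

The compounds shown leave open whether the larger step belongs to the 2-hydroxyphenyl group kept in compound 3 and compound 4, to the group bearing trifluoromethoxy, or to both together, as the core of compound 1 and the core of compound 3 are not separated one group at a time. They also leave open how the same move would behave on further cores, and whether an amine or a carboxylic acid in place of the hydroxy group on the moved ring would give a step like the one on the core of compound 1 or the one on the core of compound 3.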